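Methyl for chloro on the aryl amine: two related pairs

This account rests on a few compounds, and the source may have more. Where it says the series, first, only, none or still open, it means among the compounds named here.

Measured compounds:
Compound 1 `COc1cc2ncnc(Nc3ccc(Cl)cc3)c2cc1OCCCCC(=O)Nc1ccc(S(N)(=O)=O)cc1` gives 31800 nM in a functional assay on NCI-H1975 cells (Homo sapiens) for antiproliferative activity, read by MTT assay, with a stated time of 72 h; on this read-out lower numbers stand for stronger inhibition and higher numbers for weaker inhibition.
Compound 2 `COc1cc2ncnc(Nc3ccc(C)cc3)c2cc1OCCCCC(=O)Nc1ccc(S(N)(=O)=O)cc1` gives 19300 nM in this assay.
Compound 3 `NS(=O)(=O)c1ccc(NC(=S)Nc2ccc3ncnc(Nc4cccc(Cl)c4)c3c2)cc1` gives 39800 nM in this assay.

Compound 3 stands highest of the three numbers, but its gap to compound 1 lies within the scatter; only its gap to compound 2 lies beyond it. The difference between the core of compound 1 and the core of compound 3 is not broken down here.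

Within the first core the change methyl in place of chloro on an aromatic carbon gave a 1.6-fold lower number from compound 1 to compound 2 (0.22 log units; within the scatter).

Compound 4 `Cc1cccc(Nc2ncnc3ccc(NC(=S)Nc4ccc(S(N)(=O)=O)cc4)cc23)c1`, not yet measured, carries the same kind of change on the core of compound 3: methyl in place of chloro on an aromatic carbon. The place is not identical in wording: in compound 1 the substituent sits para to a large group, in compound 3 meta to a large group.

For the measured compounds named here, the expectation for compound 4 rests on the single measured step, since the step from compound 1 to compound 2 was a 1.6-fold lower number from compound 1 to compound 2 (0.22 log units; within the scatter). A step of a 1.5-fold lower number from compound 3 to compound 4 (0.17 log units; within the scatter) is expected in this assay. Compound 4 is thus estimated at 27000 nM, from 12000 nM to 65000 nM.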

Compound 4, half-maximal inhibitory concentration: 35400 nM
Compound 4: the middle estimate sits 1.3-fold (0.12 log units) below what was measured; measured number inside the range.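

On the core of compound 3, methyl in place of chloro gave a 1.1-fold lower number from compound 3 to compound 4 (0.05 log units; within the scatter) in this assay. Set beside the step on the core of compound 1, this shows no detectable difference between the two cores for this change: the same change on two cores in this assay, a 1.6-fold lower number (0.22 log units; within the scatter) from compound 1 to compound 2 and a 1.1-fold lower number (0.05 log units; within the scatter) from compound 3 to compound 4, 1.5-fold (0.17 log units) apart, within the scatter of two such steps Both steps lie within the scatter, however, so the agreement shows only that the change made no readable difference on either core; it does not show that a real effect of the change carries from one core to the other, and the substituent does not stand in the same place in the two pairs.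

Open, going by these compounds, is whether a different group in place of chloro, such as trifluoromethyl or an amine, would give a step beyond the scatter on either core. Also open, on these data alone, is how the two cores would compare with the chloro and methyl groups in the same place on both.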